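The source may report more compounds than this note shows. Statements on the series, on what has been measured and on what is new or still open speak of the compounds shown alone.

The series shares one core, carried in compound 1 `COc1cc(-c2nn(-c3cccc(NC(=O)Nc4cc(C(F)(F)F)cc(C(F)(F)F)c4)c3)cc2-c2ccncc2)ccc1Cl` and compound 2 `COc1cc(-c2nn(-c3cccc(NC(=O)c4cccc(C(F)(F)F)c4)c3)cc2-c2ccncc2)ccc1Cl`; the two differ in the group attached to the anilide nitrogen. In a functional assay on SF-268 cells (Homo sapiens) for inhibition, read by sulforhodamine B assay, with a stated time of 48 h (a higher number here means a weaker inhibitor of growth, a lower number a stronger inhibitor of growth), compound 1 gives 2430 nM. For compound 2 the result is a limit of this assay and not a number: compound 2 gives > 50000 nM. Compound 2 thus stands at the edge of what this assay reports, the point marked by the limit of > 50000 nM in this assay, at which 1 of the 2 values shown sits, and the two values show the urea-bearing compound 1 inhibiting growth where the amide-bearing compound 2 does not. Compound 3 `COc1cc(-c2nn(-c3cccc(NC(=O)c4ccccc4)c3)cc2-c2ccncc2)ccc1Cl` is the next compound to be measured in this assay. The change from compound 2 to compound 3 is hydrogen in place of trifluoromethyl on an aromatic carbon. Going by the values given here, no measured step carries a comparable change, so there is nothing to lean on beyond the values of compound 1 and compound 2. Trimming the amide to benzoyl is expected to leave compound 3 in the same region, and the expected step is a step that the limit leaves unreadable from compound 2 to compound 3, none beyond the scatter. Compound 3 is therefore estimated at 60000 nM, within 20000 nM to 200000 nM, and most likely reported only as a limit again.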

Compound 3, concentration for total growth inhibition: > 100000 nM
Compound 3 was reported as a limit; the forecaster's own chance of this, stated with the estimate: 75%; middle value at least 1.6-fold (0.22 log units) away from the limit.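

In this assay compound 3 gives > 100000 nM, which is a limit and not a number. Compound 2 gives > 50000 nM, also a limit, so no step can be read between compound 2 and compound 3. The compounds shown leave open whether hydrogen in place of trifluoromethyl changes growth inhibition at all.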